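The compounds below may be only part of what the source reports. "The series", "measured", "known", "first", "only" and "open" are said of these compounds alone.

Three compounds have been measured in a functional assay on LoVo cells (Homo sapiens) for inhibition, read by MTT assay, with a stated time of 72 h; on this read-out lower numbers stand for stronger inhibition and higher numbers for weaker inhibition:

Compound 1 `Cc1noc(C)c1-c1cnc(N)c(Oc2ccc(C(=O)NC3CCCC3)cc2)n1`: 25200 nM
Compound 2 `Cc1noc(C)c1-c1cnc(N)c(Oc2ccc(C(=O)Nc3ccc(Cl)cc3)cc2)n1`: 1920 nM
Compound 3 `Cc1noc(C)c1-c1cnc(N)c(Oc2ccc(C(=O)Nc3cccc(Cl)c3)cc2)n1`: 1640 nM

Compound 3 sits at the low end of these three numbers, with compound 2 within the scatter of it and only compound 1 clearly apart. Compound 4 `Cc1noc(C)c1-c1cnc(N)c(Oc2ccc(C(=O)Nc3cc(Cl)ccn3)cc2)n1` differs from compound 3 in one place: 4-chloropyridin-2-yl in place of 3-chlorophenyl on an amide-type nitrogen. Of the measured steps, a 13-fold lower number from compound 1 to compound 2 (1.12 log units; beyond the scatter) and a 15-fold lower number from compound 1 to compound 3 (1.19 log units; beyond the scatter) concern an aromatic ring replacing a saturated one, a feature compound 4 keeps, while a 1.2-fold lower number from compound 2 to compound 3 (0.07 log units; within the scatter) shows the two chlorophenyl amides within the scatter of each other. Within the data shown here, no measured step covers exchanging a ring carbon for a nitrogen in that ring, so no step beyond the scatter is expected in this assay. Compound 4 is therefore estimated at 2000 nM, with a range of 700 nM to 6000 nM. That estimate means a 1.2-fold higher number from compound 3 to compound 4 (0.09 log units; within the scatter).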

Compound 4, half-maximal inhibitory concentration: > 100000 nM
Compound 4: no number, only a limit (the forecaster's own chance of this, stated with the estimate: 3%); middle value at least 50-fold (1.69 log units) from the limit.
By their numbers in this assay, from the lowest: compounds 3 and 2 (each within the scatter of the next); then compound 1. At a limit, above all of these: compound 4.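

Compound 4 gives no number, only a limit of the assay: the limit of > 100000 nM in this assay, at which 1 of the 4 values shown sits. Exchanging a ring carbon for a nitrogen at this amide-type nitrogen therefore matters greatly, with an at least 60-fold higher number from compound 3 to compound 4 (1.78 log units; beyond the scatter) and an at least 52-fold higher number from compound 2 to compound 4 (1.71 log units; beyond the scatter), whereas the two chlorophenyl amides differ only by a 1.2-fold lower number from compound 2 to compound 3 (0.07 log units; within the scatter). An aromatic ring alone is thus not enough here, since even the saturated cyclopentyl amide compares favourably, with an at least 3.9-fold higher number from compound 1 to compound 4 (0.59 log units; beyond the scatter).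

Whether the loss depends on the chlorine remains open, as the compounds shown do not include an unsubstituted pyridin-2-yl amide. A pyrimidin-2-yl amide would test a further ring nitrogen.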